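Replacing an aryl amine with a methylpiperazine: cytotoxicity outlook

The source may report more compounds than this note shows. Statements on the series, on what has been measured and on what is new or still open speak of the compounds shown alone.

Compound 1, `CN(c1cc2ncc(=O)[nH]c2cc1Nc1nc(-c2ccccc2)cs1)C1CCCCC1`: 62500 nM
Compound 2, `CN(c1ccccc1)c1cc2ncc(=O)[nH]c2cc1Nc1nc(-c2ccccc2)cs1`: 15900 nM

Both were tested in an ADME assay on Huh-7 cells (Homo sapiens) for cytotoxicity; a lower number here means a stronger inhibitor, a higher number a weaker inhibitor. For the measured compounds named here, compound 2 gives the lowest of the two numbers; its only neighbour is compound 1, separated by the step of a 3.9-fold lower number from compound 1 to compound 2 (0.59 log units; beyond the scatter). Compound 3, `CN1CCN(c2cc3ncc(=O)[nH]c3cc2Nc2nc(-c3ccccc3)cs2)CC1`, differs from compound 2 in one place: 4-methylpiperazin-1-yl in place of methyl(phenyl)amino on an aromatic carbon. Going by the values given here, none of the measured steps covers this exchange. Among the compounds with values here, the single known step, a 3.9-fold lower number from compound 1 to compound 2 (0.59 log units; beyond the scatter), concerns a ring swap on the same nitrogen and shows that this position can shift the number modestly, but it gives no direction for a change to a saturated ring carrying two nitrogens. The estimate therefore starts from compound 2 and allows a wide spread in either direction. Compound 3 is expected to give about 25000 nM, within 6000 nM to 100000 nM. This expected step, a 1.6-fold higher number from compound 2 to compound 3 (0.20 log units; within the scatter), stays within the scatter.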

Compound 3, half-maximal inhibitory concentration: 10200 nM
Beside the measured number, compound 3's estimate is 2.5-fold (0.39 log units) above it, and the stated range covers the measured number.
By their numbers in this assay, from the lowest: compounds 3 and 2 (each within the scatter of the next); then compound 1.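

In this assay, for the compounds shown here, the first exchange on this aromatic carbon that replaces the whole amine group, rather than one ring on its nitrogen, gives a step within the scatter (a 1.6-fold lower number from compound 2 to compound 3 (0.19 log units; within the scatter)), so 4-methylpiperazin-1-yl and methyl(phenyl)amino cannot be told apart here. The same group does separate from cyclohexyl(methyl)amino (a 6.1-fold lower number from compound 1 to compound 3 (0.79 log units; beyond the scatter)), which makes compound 1 the only one of the three that stands clearly apart, with a higher number than both others. The data offer no explanation for either step. As far as these compounds go, what a morpholine ring or a small dimethylamino group would give on this aromatic carbon stays open. So does the part played by the methyl on the piperazine ring, which only a piperazine with a hydrogen or an ethyl group there could show.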